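A few compounds are considered here, and "the series" means these few. Any claim that something is new, unique, unknown or untested is made for them only; others in the source may bear on it.

Compound 3, with structure `COc1cc(-c2nn(-c3cccc(NC(=O)Nc4ccc(Cl)c(C(F)(F)F)c4)c3)cc2-c2ccncc2)ccc1Cl`, is the weaker of the two compounds that return a number in a functional assay on Hs-578T cells (Homo sapiens) for inhibition, read by sulforhodamine B assay, with a stated time of 48 h; on this read-out lower numbers stand for stronger inhibition of growth and higher numbers for weaker inhibition of growth: compound 3 gives 18300 nM, while compound 2, with structure `O=C(Nc1cccc(-n2cc(-c3ccncc3)c(-c3ccc(Cl)c(O)c3)n2)c1)Nc1ccc(Cl)c(Cl)c1`, gives 3150 nM. Compound 1, with structure `O=C(Nc1cccc(-n2cc(-c3ccncc3)c(-c3ccc(Cl)c(O)c3)n2)c1)Nc1cccc(C(F)(F)F)c1`, returns only a limit of the assay in this assay, > 32500 nM, so no number is known for it. Among the measured compounds shown here, the one measured step, an at least 10-fold lower number from compound 1 to compound 2 (1.01 log units; beyond the scatter), was large and concerns the urea end of the molecule, not the other end.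

Compound 4, with structure `O=C(Nc1cccc(-n2cc(-c3ccncc3)c(-c3ccc(Cl)c(O)c3)n2)c1)Nc1ccc(Cl)c(C(F)(F)F)c1`, is not yet measured. It differs from compound 3 by hydrogen in place of methyl on an oxygen on an aromatic ring. For the measured compounds named here, no measured step follows this change, so the single known step gives no direct guide to its size or direction. Compound 2 and compound 1 both already carry the hydroxy group, and their numbers bracket what a hydroxy compound with a urea aryl group between theirs might give. The step from compound 3 to compound 4 is therefore expected to be a 2.6-fold lower number from compound 3 to compound 4 (0.42 log units; beyond the scatter), and compound 4 is estimated at 7000 nM, within a range from 1500 nM to 30000 nM.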

Compound 4, concentration for total growth inhibition: 11200 nM
The estimate for compound 4 lay 1.6-fold (0.20 log units) below the measured number; the range from low to high includes it.
By their numbers in this assay, from the lowest: compound 2; then compounds 4 and 3 (each within the scatter of the next). At a limit, above all of these: compound 1.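

Replacing methoxy with hydroxy, the change from 4-chloro-3-methoxyphenyl to 4-chloro-3-hydroxyphenyl, gives a 1.6-fold lower number from compound 3 to compound 4 (0.21 log units; within the scatter) in this assay; this step lies within the scatter, so with this urea aryl group the two groups cannot be told apart. The other end of the molecule again moves the number: trifluoromethyl in place of chloro gives a 3.6-fold higher number from compound 2 to compound 4 (0.55 log units; beyond the scatter), and chloro in place of hydrogen gives an at least 2.9-fold lower number from compound 1 to compound 4 (0.46 log units; beyond the scatter). Compound 1 stands at a limit of the assay, so that last step is a bound and not a measured size: the limit of > 32500 nM in this assay, at which 1 of the 4 values shown sits.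

On these data alone, the methoxy and hydroxy pair is compared here on one urea aryl group only, and whether the two also match with other urea aryl groups stays open. As far as these compounds go, how an amine or an ethoxy group would read at this place also stays open.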